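A Methylsulfonyl Swap Repeated on a Second Benzamide Core

The source may report more compounds than this note shows. Statements on the series, on what has been measured and on what is new or still open speak of the compounds shown alone.

Compound 1 `O=C(Nc1ccc(Cl)c(-c2nnc3c(Cl)cccn23)c1)c1ccc(Cl)cc1` is a benzamide that, in a functional assay on MCF7 cells (Homo sapiens) for antiproliferative activity, read by MTT assay, with a stated time of 72 h (on this read-out lower numbers stand for stronger inhibition and higher numbers for weaker inhibition), gives 58400 nM. Compound 2 `CS(=O)(=O)c1ccc(C(=O)Nc2ccc(Cl)c(-c3nnc4c(Cl)cccn34)c2)cc1` carries methylsulfonyl in place of chloro on an aromatic carbon, and in this assay compound 2 gives 94200 nM, so the step was a 1.6-fold higher number from compound 1 to compound 2 (0.21 log units; within the scatter). Compound 3 `O=C(Nc1ccc(Cl)c(-c2nnc3c(Cl)cccn23)c1)c1ccc(Cl)cc1Cl` differs from compound 1 by chloro in place of hydrogen on an aromatic carbon; in this assay compound 3 gives 78200 nM. All three numbers sit close together.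

Compound 4 `CS(=O)(=O)c1ccc(C(=O)Nc2ccc(Cl)c(-c3nnc4c(Cl)cccn34)c2)c(Cl)c1` has not yet been measured. It differs from compound 3 by methylsulfonyl in place of chloro on an aromatic carbon, the same kind of change as that from compound 1 to compound 2, though the surroundings differ: here the place is also meta to a chloro group (1 heavy atom), whereas in compound 2 it is only para to a large group. Because a 1.6-fold higher number from compound 1 to compound 2 (0.21 log units; within the scatter) stayed within the scatter, a step of about the same size is expected here, a 1.6-fold higher number from compound 3 to compound 4 (0.20 log units; within the scatter). Compound 4 is therefore estimated at 125000 nM in this assay, with a likely range from 60000 nM to 260000 nM.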

Compound 4, half-maximal inhibitory concentration: > 100000 nM
Compound 4 gave a limit, no number; the forecaster's own chance of this, stated with the estimate: 30%; the middle value is on the limit's open side.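

In this assay compound 4 gave a limit and not a number, so both new steps are known only as floors: methylsulfonyl in place of chloro gives an at least 1.2-fold higher number from compound 3 to compound 4 (0.10 log units; that floor lies within the scatter), and chloro in place of hydrogen gives an at least 1.0-fold higher number from compound 2 to compound 4 (0.02 log units; that floor lies within the scatter). The methylsulfonyl change therefore cannot be said either to carry over unchanged to the second core or to behave differently there: the same change on two cores in this assay, a 1.6-fold higher number (0.21 log units; within the scatter) from compound 1 to compound 2 and an at least 1.2-fold higher number (0.10 log units; that floor lies within the scatter) from compound 3 to compound 4; the limit leaves it open whether they differ The chloro change is just as unsettled when it is carried from the core of compound 1 to the methylsulfonyl compounds: the same change on two cores in this assay, a 1.3-fold higher number (0.13 log units; within the scatter) from compound 1 to compound 3 and an at least 1.0-fold higher number (0.02 log units; that floor lies within the scatter) from compound 2 to compound 4; the limit leaves it open whether they differ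

On these data alone, how far the true value of compound 4 lies past the limit remains open, and so does the real size of both steps. Also open is whether another group in the place of the methylsulfonyl, such as an amine or a carboxylic acid, would give a number that can be read on this core: the limit of > 100000 nM in this assay, at which 1 of the 4 values shown sits.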